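This account rests on a few compounds, and the source may have more. Where it says the series, first, only, none or still open, it means among the compounds named here.

Measured in a functional assay on the whole organism for inhibition, with Rattus norvegicus as the target; on this read-out higher numbers stand for an effect only at larger amounts of compound and lower numbers for an effect already at smaller amounts:
Compound 1 `CC(C)c1ccc(OC(Cc2ccccc2)C(=O)O)cc1`: 50 mg/kg
Compound 2 `COc1ccc(OC(Cc2ccc(Cl)cc2)C(=O)O)cc1`: > 25 mg/kg (a limit)
Compound 3 `CC(C)c1ccc(OC(C)(Cc2ccccc2)C(=O)O)cc1`: > 10 mg/kg (a limit)

Compound 3 is known only through its limit of > 10 mg/kg, so it has no exact place on the scale. Compound 4 `CCc1ccc(CC(C)(Oc2ccc(C(C)C)cc2)C(=O)O)cc1` takes compound 3 one change further: ethyl in place of hydrogen on an aromatic carbon. This puts ethyl in place of hydrogen on an aromatic carbon, turning phenyl to 4-ethylphenyl.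

Among the measured compounds shown here, only one measured step bears on this, and only loosely: a step that the limit leaves unreadable from compound 1 to compound 3. It lies at a different place in the molecule and gives no size to carry over. For the measured compounds named here, no measured pair shows what ethyl does at this position, so nothing sets a direction, and no step beyond the usual scatter is expected in this assay. Going by the values given here, the estimate therefore leans on compound 1, the only compound with a full number, at 50 mg/kg. The expected change is a step that the limit leaves unreadable from compound 3 to compound 4. For compound 4 the estimated dose is 30 mg/kg, with an expected range of 10 mg/kg to 100 mg/kg.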

Compound 4, dose for half-maximal effect: 0.1 mg/kg
Compound 4: the middle estimate sits 300-fold (2.48 log units) above what was measured; the whole stated range lies above it.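

In this assay, the change from phenyl to 4-ethylphenyl brings an at least 100-fold lower number from compound 3 to compound 4 (2.00 log units; beyond the scatter) and gives the first readable step among these compounds. It shows that this aromatic carbon, para to a large group, is highly sensitive, as an ethyl group of just 2 carbon atoms is enough to produce a large change on the shared core. The limits shown say nothing about why ethyl has an effect of this size at this position.

On these data alone, whether the step is specific to ethyl remains open, as a propyl chain, a hydroxyl group or an amine at the same position could give a different result. Also open, as far as these compounds go, is how far the step depends on the methyl on the chain carbon, which compound 3 and compound 4 share.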